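Cytotoxicity of chromone acrylamides: amide substituent changes

The source may report more compounds than this note shows. Statements on the series, on what has been measured and on what is new or still open speak of the compounds shown alone.

Measured compounds:
- compound 1, `O=C(/C=C/c1coc2cc(O)ccc2c1=O)NCc1ccc(F)cc1`: 357000 nM
- compound 2, `COc1ccc2c(=O)c(/C=C/C(=O)Nc3cc(C)ccc3C)coc2c1`: 1100000 nM
- compound 3, `Cc1ccccc1NC(=O)/C=C/c1coc2cc(O)ccc2c1=O`: 374000 nM

All three were tested in an ADME assay on HepG2 2.2.15 cells (Homo sapiens) for cytotoxicity, read by MTT assay, with stated times of 48 h and 9 days; a higher number here means that more compound is tolerated, a lower number that less compound is tolerated. Compound 2 stands highest of the three numbers, beyond the scatter from both compound 3 and compound 1. Compound 2 also carries a methoxy group on the shared core where compound 1 and compound 3 carry a hydroxyl, and the amide substituent differs as well, so the two values only show that compound 2 is tolerated at the higher concentration.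

Among the measured compounds shown here, the single step that touches only the amide nitrogen is a 1.0-fold higher number from compound 1 to compound 3 (0.02 log units; within the scatter), which left the number unchanged.

Compound 4, `CCOc1ccc(NC(=O)/C=C/c2coc3cc(OC)ccc3c2=O)cc1`, is not yet measured. It differs from compound 2 by 4-ethoxyphenyl in place of 2,5-dimethylphenyl on an amide-type nitrogen. This is again a change of the group on the amide nitrogen with the rest of the structure held. For the measured compounds named here, because the only comparable step, a 1.0-fold higher number from compound 1 to compound 3 (0.02 log units; within the scatter), lay within the scatter, no step beyond the scatter is expected here either, and the estimated step of a 1.2-fold lower number from compound 2 to compound 4 (0.09 log units; within the scatter) is set near zero with a slight allowance for a lower number. Compound 4 is therefore expected to give about 900000 nM in this assay, in the range 400000 nM to 2000000 nM.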

Compound 4, half-maximal cytotoxic concentration: 460000 nM
Compound 4: the middle estimate sits 2.0-fold (0.29 log units) above what was measured; measured number inside the range.
By their numbers in this assay, from the lowest: compounds 1, 3 and 4 (each within the scatter of the next); then compound 2.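

In this assay the group on the amide-type nitrogen can move the number: the step is a 2.4-fold lower number from compound 2 to compound 4 (0.38 log units; beyond the scatter) here and a 1.0-fold higher number from compound 1 to compound 3 (0.02 log units; within the scatter) in the earlier pair of this kind. The two pairs differ in the core, methoxy in compound 2 and compound 4, hydroxyl in compound 1 and compound 3, and they exchange different groups, so the result shows only that this nitrogen is not silent in every pair, not that one core responds more than the other. Here 4-ethoxyphenyl, with its oxygen and one hydrogen-bond acceptor, replaces 2,5-dimethylphenyl, which has neither, but no measurement at hand bears on why the number falls with this exchange.

Open, from the compounds shown here alone, is whether the lower number goes with the ethoxy group or with the loss of the two methyl groups, which a plain phenyl or a 4-methoxyphenyl group on the same nitrogen would help to separate. Also open, going by these compounds, are the size of the same exchange on the hydroxyl core of compound 3, and how an amine or a carboxylic acid on the amide substituent would read.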